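A few compounds are considered here, and "the series" means these few. Any claim that something is new, unique, unknown or untested is made for them only; others in the source may bear on it.

Compound 1, `Cc1c(/N=C/c2cccc(O)c2)c(=O)n(-c2ccccc2)n1C`, gives 437000000 nM in a functional assay on P388 cells (Mus musculus) for cytotoxicity, read by MTT assay, with a stated time of 72 h; a higher number here means a weaker inhibitor, a lower number a stronger inhibitor.
Compound 2, `Cc1c(/N=C/c2cccc([N+](=O)[O-])c2)c(=O)n(-c2ccccc2)n1C`, gives 490000000 nM in this assay.
Compound 3, `Cc1c(/N=C/c2ccccc2)c(=O)n(-c2ccccc2)n1C`, gives 240000000 nM in this assay.

All three share one core and differ only in one group on the outer aromatic ring. Compound 3, which carries hydrogen there, has the lowest of the three numbers. Seen from it, a 1.8-fold lower number from compound 1 to compound 3 (0.26 log units; within the scatter) is within the usual scatter, so those two cannot be ranked, while a 2.0-fold lower number from compound 2 to compound 3 (0.31 log units; beyond the scatter) is a modest step beyond the scatter.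

Compound 4, `Cc1c(/N=C/c2cccc(Cl)c2)c(=O)n(-c2ccccc2)n1C`, has not yet been measured. It differs from compound 3 by chloro in place of hydrogen on an aromatic carbon. The two measured steps that touch the same place are a 1.8-fold lower number from compound 1 to compound 3 (0.26 log units; within the scatter) and a 2.0-fold lower number from compound 2 to compound 3 (0.31 log units; beyond the scatter): a hydroxy and a nitro group at that carbon gave slightly higher numbers than hydrogen, one inside the scatter and one just beyond it. For the measured compounds named here, a chloro group is a different substituent from either, and no measured compound carries a halogen, so the evidence is thin. On this basis compound 4 is expected to sit close to compound 3, with a small step of a 1.3-fold higher number from compound 3 to compound 4 (0.10 log units; within the scatter) toward a slightly higher number, most likely within the scatter. The estimate for compound 4 in this assay is 300000000 nM, with a range from 150000000 nM to 600000000 nM.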

Compound 4, half-maximal inhibitory concentration: 550000000 nM
Compound 4: middle estimate off by 1.8-fold (0.26 log units), on the low side; measured number inside the range.
By their numbers in this assay, from the lowest: compounds 3, 1, 2 and 4 (each within the scatter of the next, the first and the last beyond it).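

Measured in this assay and set against hydrogen, the chloro group gives a 2.3-fold higher number from compound 3 to compound 4 (0.36 log units; beyond the scatter) and so becomes the second group at this aromatic carbon, after nitro, to stand clearly apart from hydrogen, although compound 1 goes against any rule that every added group does this, since its hydroxy group remains within the scatter of compound 3. Among the three substituted compounds, the data show a 1.1-fold higher number from compound 2 to compound 4 (0.05 log units; within the scatter) and also a 1.3-fold higher number from compound 1 to compound 4 (0.10 log units; within the scatter) and both steps are within the scatter, so chloro, nitro and hydroxy cannot be ranked against one another at this position. No accompanying measurement offers an explanation for the step from hydrogen to chloro.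

From the compounds shown here alone, it remains open whether other groups at this carbon, such as an amine, a carboxylic acid, a methoxy group or a longer chain, would stay level with these three substituted compounds or come nearer to compound 3. The compounds shown also change only this one place, so they leave open how changes elsewhere on the shared core would alter the number.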